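The source may report more compounds than this note shows. Statements on the series, on what has been measured and on what is new or still open speak of the compounds shown alone.

Measured compounds:
compound 1, `CCCC(=O)N1CCC(NS(=O)(=O)c2ccc(NC(=O)c3ccc(F)cc3)c3ccccc23)CC1`: 59.5 nM
compound 2, `CCOC(=O)N1CCC(NS(=O)(=O)c2ccc(NC(=O)c3ccncc3)c3ccccc23)CC1`: 100 nM

The two measured compounds share a core and differ in the groups at both ends of it. In an in vitro functional assay on CHO/Galpha16 cells for antagonist activity at C-C chemokine receptor type 8 (Homo sapiens), read by FLIPR (a lower number here means a stronger inhibitor, a higher number a weaker inhibitor), compound 1 gives 59.5 nM, and compound 2 gives 100 nM. Their two numbers lie within the scatter of each other, so compound 1 cannot be set apart from compound 2 on this evidence; it simply stands at one of two closely placed values.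

Compound 3, `CCCC(=O)N1CCC(NS(=O)(=O)c2ccc(NC(=O)C3CCCC3)c3ccccc23)CC1`, keeps the core of compound 1 and changes only the amide end: cyclopentyl in place of 4-fluorophenyl on a carbonyl carbon. Within the data shown here, no measured pair shows this kind of change, so its effect in this assay is not known from the data. An aromatic ring gives way to a saturated one of different size, and a modest shift toward a higher number is expected rather than a large one, though a value within the scatter of compound 1 is also possible.

For compound 3 the expected value in this assay is 120 nM, within a range of 40 nM to 400 nM. This estimate amounts to an expected step of a 2.0-fold higher number from compound 1 to compound 3 (0.30 log units; within the scatter).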

Compound 3, half-maximal inhibitory concentration: 365 nM
For compound 3 the middle estimate is 3.0-fold (0.48 log units) below the measured one, and the stated range covers the measured number.
By their numbers in this assay, from the lowest: compounds 1 and 2 (each within the scatter of the next); then compound 3.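

In this assay, cyclopentyl in place of 4-fluorophenyl on a carbonyl carbon gives a 6.1-fold higher number from compound 1 to compound 3 (0.79 log units; beyond the scatter) and so supplies the first change in one place among these compounds. It shows that the group on this carbonyl carbon matters on the shared core with the butanoyl end held fixed, and that this exchange costs inhibition by more than the usual scatter. Nothing at hand explains the step.

The single step changes ring size, aromatic character and the fluorine together, so the compounds shown cannot tell which of these counts. Plain phenyl, cyclohexyl or a 4-chlorophenyl group on the same carbonyl carbon would separate them, and whether the same step holds with the ethyl carbamate end of compound 2 also remains open.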